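Ethyl for Methyl on a Urea Scaffold in Rice

A few compounds are considered here, and "the series" means these few. Any claim that something is new, unique, unknown or untested is made for them only; others in the source may bear on it.

Measured so far in an ADME assay on the whole organism with Oryza sativa as the target, tested at 0.1 uM; a higher number here means a weaker effect of the compound at the concentration tested, a lower number a stronger effect:
compound 1, `Cc1cccc(NC(=O)N[C@H](C)c2ccccc2)c1`, 100%
compound 2, `Cc1ccc(NC(=O)N[C@H](C)c2ccccc2)cc1`, 100%
compound 3, `CCc1cccc(NC(=O)N[C@H](C)c2ccccc2)c1`, 97%

Compound 1 and compound 2 share the same atoms joined differently; how the two cores differ is not broken down here. Compound 3 arises from compound 1 by methyl in place of hydrogen on a saturated chain carbon bound to an aromatic carbon, and this change gave a number 3 percentage points lower from compound 1 to compound 3 (within the scatter). Compound 4, `CCc1ccc(NC(=O)N[C@H](C)c2ccccc2)cc1`, is not yet measured; it arises from compound 2 by methyl in place of hydrogen on a saturated chain carbon bound to an aromatic carbon, the same change made on the other core. Because a number 3 percentage points lower from compound 1 to compound 3 (within the scatter) stayed within the scatter, the step is expected to be small again: compound 4 is estimated at a number 2 percentage points lower from compound 2 to compound 4 (within the scatter) from compound 2. Compound 4 is therefore estimated at 98% in this assay, most likely between 90% and 100%, resting only on one earlier step of the same kind.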

Compound 4, a percentage reported as activity, at one concentration (the size of the read-out at that concentration, not a potency): 95%
The estimate for compound 4 lay 3 percentage points above the measured number; the measured number falls inside the stated range.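

In this assay, the change from methyl to ethyl gave a number 5 percentage points lower from compound 2 to compound 4 (within the scatter). Set beside the earlier step, the same change behaved alike on both cores: the same change on two cores in this assay, a number 3 percentage points lower (within the scatter) from compound 1 to compound 3 and a number 5 percentage points lower (within the scatter) from compound 2 to compound 4, 2 percentage points apart, within the scatter of two such steps. This shows that, on these two cores, the change left the read-out within the usual scatter; it does not show that ethyl and methyl truly differ in effect, and two pairs cannot show that the same would hold on any other core.

The compounds shown leave open whether a longer chain, such as propyl, would move the number beyond the scatter. They also leave open what an amine or a carboxylic acid would do in the place of the ethyl.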